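This account rests on a few compounds, and the source may have more. Where it says the series, first, only, none or still open, it means among the compounds named here.

In a functional assay on L1210 cells (Mus musculus) for antiproliferative activity (on this read-out higher numbers stand for weaker inhibition and lower numbers for stronger inhibition), compound 3 `COc1cc(C(=O)c2sc(-c3ccc([N+](=O)[O-])cc3)cc2N)cc(OC)c1OC` gives 100 nM, the higher of the two exact numbers available. Compound 2 `COc1ccc(-c2cc(N)c(C(=O)c3cc(OC)c(OC)c(OC)c3)s2)cc1OC` gives 40 nM. Compound 1 `COc1cc(C(=O)c2sc(-c3ccc(-c4ccccc4)cc3)cc2N)cc(OC)c1OC` gives > 10000 nM, which is a limit of the assay and not a number. Compound 4 `COc1cc(C(=O)c2sc(-c3ccc(Cl)cc3)cc2N)cc(OC)c1OC` differs from compound 3 by chloro in place of nitro on an aromatic carbon. Two measured steps alter the same part of the structure. The large at least 100-fold lower number from compound 1 to compound 3 (2.00 log units; beyond the scatter) shows how much that part can matter, while a 2.5-fold higher number from compound 2 to compound 3 (0.40 log units; beyond the scatter) is only modest. Neither step tests chloro, so no step beyond the scatter is expected in this assay. The estimated change is a 1.5-fold higher number from compound 3 to compound 4 (0.18 log units; within the scatter). For compound 4 the expected value is 150 nM, within an estimated range of 40 nM to 600 nM.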

Compound 4, half-maximal inhibitory concentration: 93 nM
Estimate against measurement, compound 4: 1.6-fold (0.21 log units) above; the measured number falls inside the stated range.
By their numbers in this assay, from the lowest: compound 2; then compounds 4 and 3 (each within the scatter of the next). At a limit, above all of these: compound 1.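

At this place, para to a large group, chloro matches nitro in this assay: there is a 1.1-fold lower number from compound 3 to compound 4 (0.03 log units; within the scatter). Compound 4 therefore stays apart from the 3,4-dimethoxyphenyl compound just as compound 3 does, with a 2.3-fold higher number from compound 2 to compound 4 (0.37 log units; beyond the scatter). For the compounds shown here, the phenyl group remains the one change with a large effect, with an at least 100-fold lower number from compound 1 to compound 4 (2.03 log units; beyond the scatter), and this step rests on the limit of compound 1.

As far as these compounds go, whether an amine or a methyl group here would fall with chloro and nitro stays open. From the compounds shown here alone, how far compound 1 lies from the others also stays open, as its value is a limit: the limit of > 10000 nM in this assay, at which 1 of the 4 values shown sits.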